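The source may hold more compounds than are shown below. What is called first, only, known or untested is meant among the compounds shown, and "the series" means these compounds.

For the measured compounds named here, compound 1 `COc1ccc([C@@H]2CC(=O)c3c(O)cc(OCc4cn(C5CCCC5)nn4)cc3O2)cc1O` gives 10500 nM in a functional assay on RAW264.7 cells (Mus musculus) for inhibition, read by Griess assay, with stated times of 2 h and 24 h (a higher number here means a weaker inhibitor, a lower number a stronger inhibitor), one of only two numbers measured here. Compound 2 `C#CCOc1cc(O)c2c(c1)O[C@H](c1ccc(OC)c(O)c1)CC2=O` gives 20900 nM in this assay, and the step of a 2.0-fold higher number from compound 1 to compound 2 (0.30 log units; within the scatter) stays within the scatter, so the two cannot be told apart. Compound 3 `COc1ccc([C@@H]2CC(=O)c3c(O)cc(OCc4cn(Cc5ccccc5C(F)(F)F)nn4)cc3O2)cc1O` differs from compound 1 by 2-(trifluoromethyl)benzyl in place of cyclopentyl on an aromatic nitrogen. Going by the values given here, no measured step touches this group on the aromatic nitrogen; the single known step, which swaps the whole ring-bearing group for ethynyl, changed little, so no step beyond the scatter is expected in this assay. Compound 3 is thus expected to give about 10000 nM, most likely between 4000 nM and 30000 nM. The expected step is a 1.1-fold lower number from compound 1 to compound 3 (0.02 log units; within the scatter).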

Compound 3, half-maximal inhibitory concentration: 12500 nM
Estimate against measurement, compound 3: 1.3-fold (0.10 log units) below, within the range that was stated.
By their numbers in this assay, from the lowest: compounds 1, 3 and 2 (each within the scatter of the next).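

In this assay, for the compounds shown here, the group on the aromatic nitrogen is now varied directly, which the earlier compounds did not do. Putting 2-(trifluoromethyl)benzyl, with 11 heavy atoms and an aromatic ring, in place of cyclopentyl, with 5 heavy atoms, gives a 1.2-fold higher number from compound 1 to compound 3 (0.08 log units; within the scatter). For these two groups, then, size and ring type at this position make no difference that can be told from the scatter, and no other information here bears on this result. Both groups carry no hydrogen-bond donors or acceptors and no net charge. Going by these compounds, how an amine or a carboxylic acid on this nitrogen would read in this assay remains open.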